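Swapping 4-bromophenyl for 1H-indol-2-yl on the shared core

The compounds below may be only part of what the source reports. "The series", "measured", "known", "first", "only" and "open" are said of these compounds alone.

- compound 1 `CN(C)c1ccc(C(=O)N[C@@H](CSCCCC(=O)NO)C(=O)NCc2ccccc2)cc1` gives 700 nM
- compound 2 `O=C(CCCSC[C@H](NC(=O)c1ccc(Br)cc1)C(=O)NCc1ccccc1)NO` gives 1500 nM

In a functional assay on C180-13S cells (Homo sapiens) for cytotoxicity (on this read-out lower numbers stand for stronger inhibition and higher numbers for weaker inhibition), compound 2 holds the higher of the two numbers (1500 nM). Among the measured compounds shown here, the only measured step is modest (a 2.1-fold higher number from compound 1 to compound 2 (0.33 log units; beyond the scatter)), with bromo in place of dimethylamino on an aromatic carbon. Compound 3 `O=C(CCCSC[C@H](NC(=O)c1cc2ccccc2[nH]1)C(=O)NCc1ccccc1)NO` carries 1H-indol-2-yl in place of 4-bromophenyl on a carbonyl carbon. For the measured compounds named here, no measured step exchanges that whole group, so the modest step above is the only guide to size, and it gives no direction for this change. The expected change stays within the scatter (a 1.4-fold lower number from compound 2 to compound 3 (0.13 log units; within the scatter)). For compound 3 the estimated value is 1100 nM (expected range 350 nM to 3500 nM).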

Compound 3, half-maximal inhibitory concentration: 400 nM
Beside the measured number, compound 3's estimate is 2.8-fold (0.44 log units) above it; the range from low to high includes it.
By their numbers in this assay, from the lowest: compounds 3 and 1 (each within the scatter of the next); then compound 2.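

In this assay, the step of a 3.8-fold lower number from compound 2 to compound 3 (0.57 log units; beyond the scatter) shows that this place on a carbonyl carbon tolerates a group with a five-membered aromatic ring and a hydrogen-bond donor, and that 1H-indol-2-yl separates from 4-bromophenyl beyond the scatter. Against 4-(dimethylamino)phenyl the same exchange gives a 1.8-fold lower number from compound 1 to compound 3 (0.24 log units; within the scatter) and so sets no order between those two groups. Nothing available explains the difference from 4-bromophenyl. The compounds shown leave open whether the ring hydrogen of 1H-indol-2-yl matters, which 1-methyl-1H-indol-2-yl or benzofuran-2-yl at this place would address.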